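A chloro group on the phenyl of compound 2

The source may report more compounds than this note shows. Statements on the series, on what has been measured and on what is new or still open speak of the compounds shown alone.

Compound 1 `O=C(Nc1ccccc1)C1(c2ccccc2)CCCC1` does not return a number in an ADME assay on MDCK cells (Canis lupus familiaris) for cytotoxicity (on this read-out higher numbers stand for lower toxicity in this test and lower numbers for higher toxicity in this test), but only the limit of > 100000 nM, a ceiling described by the limit of > 100000 nM in this assay, at which 1 of the 3 values shown sits. Compound 2 `CN(C(=O)C1(c2ccccc2)CCCC1)c1ccccc1` gives 52000 nM in this assay, the higher of the two numbers that are not limits. Compound 3 `CN(C(=O)C1(c2cccc(C(F)(F)F)c2)CCCC1)c1ccccc1` gives 20000 nM in this assay. The two measured steps are an at least 1.9-fold lower number from compound 1 to compound 2 (0.28 log units; that floor lies within the scatter) and a 2.6-fold lower number from compound 2 to compound 3 (0.41 log units; beyond the scatter); the first rests on a limit and lies within the scatter, the second is modest and beyond it.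

Compound 4 `CN(C(=O)C1(c2ccc(Cl)cc2)CCCC1)c1ccccc1` differs from compound 2 by chloro in place of hydrogen on an aromatic carbon. The step that bears on this change is the one in which a substituent likewise enters an aromatic carbon of the same phenyl, namely a 2.6-fold lower number from compound 2 to compound 3 (0.41 log units; beyond the scatter). Among the measured compounds shown here, whether a single chlorine moves the number as far as trifluoromethyl cannot be read from only one such step, so the expected step is in the same direction but of smaller size: a 1.6-fold lower number from compound 2 to compound 4 (0.21 log units; within the scatter) is what is expected in this assay. Compound 4 is therefore estimated at 32000 nM in this assay, with a range from 13000 nM to 80000 nM that allows for a result no different from compound 2 within the scatter.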

Compound 4, half-maximal cytotoxic concentration: 21000 nM
Compound 4: middle estimate off by 1.5-fold (0.18 log units), on the high side, and the stated range covers the measured number.
By their numbers in this assay, from the lowest: compounds 3 and 4 (each within the scatter of the next); then compound 2. At a limit, above all of these: compound 1.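

In this assay, a single chlorine, para to a large group, is enough to give a 2.5-fold lower number from compound 2 to compound 4 (0.39 log units; beyond the scatter), a modest change but one that stands beyond the scatter. Until now, only trifluoromethyl had shown such a change on this phenyl, in a 2.6-fold lower number from compound 2 to compound 3 (0.41 log units; beyond the scatter); with chloro there are two different groups, and in both steps the number falls from that of the unsubstituted phenyl, with neither compound going against this among those shown. Nothing measured here bears on the cause of the change from phenyl to 4-chlorophenyl.

The compounds shown leave open whether chloro would give a similar step on another aromatic carbon of this phenyl, and whether an amine, a carboxylic acid or a methoxy group on the same carbon would also lower the number or would leave it where compound 2 stands. They also leave open whether chloro on the phenyl carried by the amide-type nitrogen would change the number in the same way.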